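Purine Ribosides with Benzylamine Tails: From Compound 3 to 4

The compounds below may be only part of what the source reports. "The series", "measured", "known", "first", "only" and "open" are said of these compounds alone.

The measured compounds in a functional assay on HOS cells (Homo sapiens) for antiproliferative activity, with a stated time of 72 h; a lower number here means a stronger inhibitor, a higher number a weaker inhibitor:
Compound 1 `OC[C@H]1O[C@@H](n2cnc3c(NCc4ccc(F)cc4)ncnc32)[C@H](O)[C@@H]1O`: 13200 nM
Compound 2 `COc1ccccc1CNc1ncnc2c1ncn2[C@@H]1O[C@H](CO)[C@@H](O)[C@H]1O`: > 166000 nM
Compound 3 `COc1cccc(CNc2ncnc3c2ncn3[C@@H]2O[C@H](CO)[C@@H](O)[C@H]2O)c1OC`: > 166000 nM

The three share one core and differ only in the aryl group on the saturated chain carbon bound to a nitrogen on the aromatic ring. Within the data shown here, compound 1, with its 4-fluorophenyl, is the only one with a number. Compound 2 gives only a limit of the assay. Compound 3 likewise gives only a limit, so it stands at the weak end of what was measured, as the limit of > 166000 nM in this assay, at which 2 of the 3 values shown sit, shows. The steps of an at least 12-fold higher number from compound 1 to compound 2 (1.09 log units; beyond the scatter) and an at least 12-fold higher number from compound 1 to compound 3 (1.09 log units; beyond the scatter) are both large; the step that the two limits leave unreadable from compound 2 to compound 3 cannot be read.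

Compound 4 `Cc1ccc(O)c(CNc2ncnc3c2ncn3[C@@H]2O[C@H](CO)[C@@H](O)[C@H]2O)c1` carries the change (2-hydroxy-5-methylphenyl in place of 2,3-dimethoxyphenyl on a saturated chain carbon bound to a nitrogen on an aromatic ring). Among the measured compounds shown here, no measured step covers a hydroxyl or methyl on this aryl group, and compound 3 starts at a limit, so the estimated step of an at least 1.6-fold lower number from compound 3 to compound 4 (0.22 log units; that floor lies within the scatter) is expected to be poorly defined. The estimate for compound 4 is 100000 nM, between 15000 nM and 300000 nM.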

Compound 4, half-maximal inhibitory concentration: > 166000 nM
Compound 4: a limit, no number; the forecaster's own chance of this, stated with the estimate: 50%; at least 1.6-fold (0.22 log units) between middle value and limit.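

In this assay, compound 4 gives only a limit and no number, which puts a third aryl group at the weak end of this set: the limit of > 166000 nM in this assay, at which 3 of the 4 values shown sit. The change of the 4-fluorophenyl to a 2-hydroxy-5-methylphenyl gives an at least 12-fold higher number from compound 1 to compound 4 (1.09 log units; beyond the scatter), so an aryl group with a hydroxyl and a methyl, and no methoxy, also stays far from the reading of compound 1 at this position. The steps among compounds 2, 3 and 4 cannot be read, as each of those pairs consists of two limits, and so the swap of methoxy groups for a hydroxyl and a methyl has no measurable size here.

Going by these compounds, how far compounds 2, 3 and 4 lie beyond that limit remains open. So does whether a chlorine or an amine on the phenyl ring would give a number, as the fluorine of compound 1 does.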